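This account rests on a few compounds, and the source may have more. Where it says the series, first, only, none or still open, it means among the compounds named here.

Measured so far:
- compound 1 `COc1ccc(/C=C/C[C@@H]2C[C@H]([C@H](O)c3ccc(OC)c(OC)c3)CO[C@H]2c2ccc(OC)c(OC)c2)cc1OC`: "not determined" (no result reported) in a functional assay on HL-60 cells (Homo sapiens) for cytotoxicity, read by WST assay, with a stated time of 48 h; a higher number here means a weaker inhibitor, a lower number a stronger inhibitor
- compound 2 `O=[N+]([O-])c1cccc(/C=C/C[C@H]2C[C@@H]([C@@H](O)c3ccccc3)CO[C@@H]2c2ccccc2)c1`: 6350 nM in this assay

Going by the values given here, compound 1 has no number of its own in this assay, so it offers no anchor; the only value belongs to compound 2. Compound 3 `COc1ccc(/C=C/C[C@@H]2C[C@@H]([C@@H](O)c3ccc(OC)c(OC)c3)CO[C@H]2c2ccc(OC)c(OC)c2)cc1OC` keeps every atom and bond of compound 1; the difference is the two compounds have the same atoms and bonds and differ only in configuration as drawn: 2 of 5 stereo elements differ; a stereocentre at a saturated ring carbon is drawn S in compound 1 and R in compound 3; a stereocentre at a saturated chain carbon is drawn S in compound 1 and R in compound 3. Among the compounds with values here, no measured step between stereoisomers exists in this set, so neither direction nor size of the shift can be read from the data, and a shift larger than the scatter is possible either way. With the value of compound 2 as the only scale, compound 3 is expected at about 8000 nM, in a range from 2000 nM to 40000 nM.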

Compound 3, half-maximal inhibitory concentration: 26000 nM
The estimate for compound 3 lay 3.3-fold (0.51 log units) below the measured number; low and high end bracket the measured number.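

No step can be read here: in this assay compound 1 has no number, so compound 3 at 26000 nM has no value to be set beside. From the compounds shown here alone, what the shift between these stereoisomers amounts to stays open, in direction and in size.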